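A few compounds are considered here, and "the series" means these few. Any claim that something is new, unique, unknown or untested is made for them only; others in the source may bear on it.

The measured compounds in an assay on LM cells with Alpha-1B adrenergic receptor (Homo sapiens) as the target; on this read-out lower numbers stand for stronger inhibition and higher numbers for weaker inhibition:
compound 1, `CC1=C(C(=O)NCCCN2CCC(c3ccc(F)cc3C#N)CC2)[C@@H](c2ccc(F)c(F)c2)NC(=O)N1`, gives 87 nM;
compound 2, `N#Cc1cc(F)ccc1C1CCN(CCCNC(=O)C2=C(C(F)(F)F)NC(=O)N[C@@H]2c2ccc(F)c(F)c2)CC1`, gives 200 nM.

Compound 2 stands with the highest of the two numbers; its nearest neighbour is compound 1, and the step of a 2.3-fold higher number from compound 1 to compound 2 (0.36 log units; beyond the scatter) accompanies a trifluoromethyl in place of methyl on a double-bonded ring carbon. Compound 3, `O=C1NC(C(F)(F)F)=C(C(=O)NCCCN2CCC(c3ccccn3)CC2)[C@@H](c2ccc(F)c(F)c2)N1`, differs from compound 2 in another place: pyridin-2-yl in place of 2-cyano-4-fluorophenyl on a saturated ring carbon. Among the measured compounds shown here, no measured step touches this position; the single measured step concerns the double-bonded ring carbon and says nothing about the group on the saturated ring carbon. The account therefore has no footing for a direction, and the expectation for compound 3 rests on compound 2 alone, with a wide margin. Compound 3 is expected to give about 400 nM in this assay, between 100 nM and 2000 nM. The estimated step of a 2.0-fold higher number from compound 2 to compound 3 (0.30 log units; within the scatter) is thus modest in its middle value but uncertain in either direction.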

Compound 3, inhibition constant: > 2000 nM
Compound 3 was reported as a limit; the forecaster's own chance of this, stated with the estimate: 5%; middle value at least 5.0-fold (0.69 log units) away from the limit.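

Among the compounds shown here, the group on the saturated ring carbon of the six-membered ring matters far more in this assay than the one modest earlier step, at the double-bonded ring carbon, could show. Pyridin-2-yl in place of 2-cyano-4-fluorophenyl brings an at least 10-fold higher number from compound 2 to compound 3 (1.00 log units; beyond the scatter), so this position is sensitive to the change, and the direction here is towards weaker inhibition. On these data alone, the figure for compound 3 is only a limit, so the true size of this step remains unknown: the limit of > 2000 nM in this assay, at which 1 of the 3 values shown sits.

The compounds shown leave open which part of the change carries the step, since the nitrile, the fluorine and the ring nitrogen of pyridin-2-yl all differ at once; a plain phenyl or a 2-cyanophenyl at this carbon would separate them. As far as these compounds go, it is also open whether pyridin-2-yl behaves alike with methyl in place of trifluoromethyl on the double-bonded ring carbon.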